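Aryl group variation on the shared core: toward compound 4

This account rests on a few compounds, and the source may have more. Where it says the series, first, only, none or still open, it means among the compounds named here.

Measured in a functional assay on BJAB cells (Homo sapiens) for antiproliferative activity, with a stated time of 4 days; on this read-out lower numbers stand for an effect already at smaller amounts and higher numbers for an effect only at larger amounts of compound:
compound 1 `COc1cncc(-c2c(C)nn(-c3nc(-c4ccc(Cl)c(Cl)c4)c(SC(C)C)s3)c2C(=O)O)c1` gives 21000 nM
compound 2 `Cc1nn(-c2nc(-c3ccc(Cl)c(Cl)c3)c(SC(C)C)s2)c(C(=O)O)c1-c1ccccc1Cl` gives 13100 nM
compound 3 `Cc1cc(Cl)cc(-c2c(C)nn(-c3nc(-c4ccc(Cl)c(Cl)c4)c(SC(C)C)s3)c2C(=O)O)c1` gives 663 nM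

Compound 3 stands at the lowest number of the three. The step of a 20-fold lower number from compound 2 to compound 3 (1.30 log units; beyond the scatter) and the step of a 32-fold lower number from compound 1 to compound 3 (1.50 log units; beyond the scatter) are both large, whereas a 1.6-fold lower number from compound 1 to compound 2 (0.20 log units; within the scatter) remains within the scatter. Compound 4 `Cc1nn(-c2nc(-c3ccc(Cl)c(Cl)c3)c(SC(C)C)s2)c(C(=O)O)c1-c1ccccc1[N+](=O)[O-]` differs from compound 3 by 2-nitrophenyl in place of 3-chloro-5-methylphenyl on an aromatic carbon. The nearest comparison is compound 2, which carries 2-chlorophenyl on the same aromatic carbon and sits far above compound 3. The change to compound 4 is therefore expected to raise the number in this assay by a 15-fold higher number from compound 3 to compound 4 (1.18 log units; beyond the scatter), back toward the level of compound 2. Compound 4 is estimated at 10000 nM, with a range from 3000 nM to 30000 nM.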

Compound 4, half-maximal effective concentration: 4700 nM
Compound 4: the middle estimate sits 2.1-fold (0.33 log units) above what was measured; the range from low to high includes it.
By their numbers in this assay, from the lowest: compound 3; then compound 4; then compounds 2 and 1 (each within the scatter of the next).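

In this assay, nitro in place of chloro gives a 2.8-fold lower number from compound 2 to compound 4 (0.45 log units; beyond the scatter) and so shows that this position responds to the group carried on the phenyl ring, not only to the ring's presence. 2-Nitrophenyl also separates from 5-methoxypyridin-3-yl, with a 4.5-fold lower number from compound 1 to compound 4 (0.65 log units; beyond the scatter), yet it does not match 3-chloro-5-methylphenyl, with a 7.1-fold higher number from compound 3 to compound 4 (0.85 log units; beyond the scatter). No measurement at hand bears on the cause of these steps.

On these data alone, whether an amine or a nitrile in place of nitro would come closer to compound 3 remains open. So does whether the low number of compound 3 needs both its chlorine and its methyl group.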